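The compounds below may be only part of what the source reports. "The series", "measured", "known", "first", "only" and "open" are said of these compounds alone.

Three compounds of one series have been run in a functional assay on J774.A1 cells (Mus musculus) for inhibition, read by immunoassay, with a stated time of 12 h, tested at 30 uM; a higher number here means more inhibition at the concentration tested (going by the name of the read-out), a lower number less inhibition. Compound 1 `O=C1CC(c2ccccc2OCc2ccc(F)cc2)Oc2ccccc21` gives 42.1%, compound 2 `CCCOc1ccccc1C1CC(=O)c2ccccc2O1` gives 43.6%, and compound 3 `CC(C)COc1ccccc1C1CC(=O)c2ccccc2O1` gives 33.5%. Compound 3 carries the smallest of the three numbers, but the picture is uneven: the move a number 10.1 percentage points lower from compound 2 to compound 3 (beyond the scatter) is the only one that clears the scatter, whereas a number 8.6 percentage points lower from compound 1 to compound 3 (within the scatter) and a number 1.5 percentage points higher from compound 1 to compound 2 (within the scatter) do not.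

Compound 4 `C=CCOc1ccccc1C1CC(=O)c2ccccc2O1` is the next member. Compared with compound 3 the change is vinyl in place of isopropyl on a saturated chain carbon bound to an oxygen on an aromatic ring. Within the data shown here, two measured steps bear on it. The step of a number 10.1 percentage points lower from compound 2 to compound 3 (beyond the scatter) shows that a chain of three carbons at this position sits somewhat higher than the branched chain of compound 3; allyl, like propyl, is an unbranched chain of three carbons. The step of a number 8.6 percentage points lower from compound 1 to compound 3 (within the scatter) shows that larger substituents at the same place give only a shift inside the scatter. On this basis a modest rise toward the number of compound 2 is expected for compound 4, with a number 8.5 percentage points higher from compound 3 to compound 4 (within the scatter). Compound 4 is therefore estimated at 42%, with a range from 30% to 54%.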

Compound 4, a percentage reported as inhibition, at one concentration (the size of the read-out at that concentration, not a potency): 47%
Beside the measured number, compound 4's estimate is 5 percentage points below it, and the stated range covers the measured number.
By their numbers in this assay, from the lowest: compounds 3, 1, 2 and 4 (each within the scatter of the next, the first and the last beyond it).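

In this assay, vinyl in place of isopropyl on a saturated chain carbon bound to an oxygen on an aromatic ring gives a number 13.5 percentage points higher from compound 3 to compound 4 (beyond the scatter), a second step beyond the scatter that separates the isobutoxy group of compound 3 from another group at this place, although compound 1 goes against any clean split, since its step to compound 3 stays within the scatter. Vinyl in place of ethyl gives a number 3.4 percentage points higher from compound 2 to compound 4 (within the scatter) and vinyl in place of 4-fluorophenyl gives a number 4.9 percentage points higher from compound 1 to compound 4 (within the scatter), so at this place neither the double bond outside aromatic rings nor the 4-fluorophenyl group is told apart from the others by these numbers, and the one change that registers in this series remains the isobutoxy group. No measurement at hand bears on why the numbers fall this way.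

Still open, on these data alone, is whether a longer chain, an amine or a carboxylic acid on a saturated chain carbon bound to an oxygen on an aromatic ring would hold these numbers or move them. Each number also comes from a single concentration, so potency across this series remains unsettled.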